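The compounds below may be only part of what the source reports. "The series", "measured", "known", "first", "only" and "open" are said of these compounds alone.

Measured compounds:

Compound 1 `COc1ccc2[nH]cc(CCCN3CCN(C(=O)CN4CCN(C(=O)c5ccc(Cl)cc5)CC4)CC3)c2c1`: 159000 nM
Compound 2 `COc1ccc(C(=O)N2CCN(CC(=O)N3CCN(CCCc4c[nH]c5ccc(OC)cc45)CC3)CC2)cc1`: 190000 nM
Compound 3 `COc1ccc2[nH]cc(CCCN3CCN(C(=O)CN4CCN(C(=O)c5cccc(Cl)c5)CC4)CC3)c2c1`: > 200000 nM

Compound 1 `COc1ccc2[nH]cc(CCCN3CCN(C(=O)CN4CCN(C(=O)c5ccc(Cl)cc5)CC4)CC3)c2c1` and compound 2 `COc1ccc(C(=O)N2CCN(CC(=O)N3CCN(CCCc4c[nH]c5ccc(OC)cc45)CC3)CC2)cc1` share a core and differ only in one change, (methoxy in place of chloro on an aromatic carbon). In an ADME assay on SH-SY5Y cells (Homo sapiens) for cytotoxicity, read by MTT assay, with a stated time of 72 h (a lower number here means a stronger inhibitor, a higher number a weaker inhibitor), compound 1 gives 159000 nM, and in this assay compound 2 gives 190000 nM. The step of a 1.2-fold higher number from compound 1 to compound 2 (0.08 log units; within the scatter) is small. Compound 3 `COc1ccc2[nH]cc(CCCN3CCN(C(=O)CN4CCN(C(=O)c5cccc(Cl)c5)CC4)CC3)c2c1` carries a different core, and the difference from compound 1 is 3-chlorophenyl in place of 4-chlorophenyl on a carbonyl carbon. In this assay compound 3 gives only a limit, > 200000 nM, and not a number; one of the three values sits at the limit of > 200000 nM in this assay, at which 1 of the 3 values shown sits. The step of an at least 1.2-fold higher number from compound 1 to compound 3 (0.09 log units; that floor lies within the scatter) and the step of an at least 1.0-fold higher number from compound 2 to compound 3 (0.02 log units; that floor lies within the scatter) both have floors that fall within the scatter.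

Compound 4 `COc1cccc(C(=O)N2CCN(CC(=O)N3CCN(CCCc4c[nH]c5ccc(OC)cc45)CC3)CC2)c1` has not yet been measured in this assay. It differs from compound 3 by methoxy in place of chloro on an aromatic carbon. Going by the values given here, this is the same kind of change as the one from compound 1 to compound 2, but the place differs: there the methoxy sits para to a large group, here it sits meta to a large group. Compound 4 is therefore expected to show a step like a step that the limit leaves unreadable from compound 3 to compound 4, a step of about the size seen in a 1.2-fold higher number from compound 1 to compound 2 (0.08 log units; within the scatter), resting on that one measured pair. Compound 4 is estimated at 230000 nM, with a range from 150000 nM to 400000 nM, and the value may again come out only as a limit.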

Compound 4, half-maximal inhibitory concentration: > 200000 nM
Compound 4: no number, only a limit (the forecaster's own chance of this, stated with the estimate: 65%); the middle value lies beyond the limit too.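

In this assay compound 4 gives > 200000 nM, which is a limit and not a number. Compound 3 also gives only a limit, so the step of methoxy in place of chloro on this core cannot be read or set against the step on the other core, a 1.2-fold higher number from compound 1 to compound 2 (0.08 log units; within the scatter), and the reading is bounded by the assay's limit: the limit of > 200000 nM in this assay, at which 2 of the 4 values shown sit. The two remaining steps, an at least 1.0-fold higher number from compound 2 to compound 4 (0.02 log units; that floor lies within the scatter) and an at least 1.2-fold higher number from compound 1 to compound 4 (0.09 log units; that floor lies within the scatter), have floors within the scatter, so the result does not conflict with the change carrying over but does not show that it does.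

On these data alone, it remains open what the change does on the core of compound 3 when both compounds fall short of a measurable value, since one measured pair is all that exists for it. As far as these compounds go, it is also open whether an amine, a carboxylic acid or a longer chain in place of chloro or methoxy on this aromatic carbon would give a number inside the limit in this assay.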